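This account rests on a few compounds, and the source may have more. Where it says the series, first, only, none or still open, it means among the compounds named here.

Working notes on the series

Three compounds of this set have been run in a functional assay on HepG2 cells (Homo sapiens) for inhibition, read by MTT assay, with a stated time of 72 h; on this read-out higher numbers stand for weaker inhibition and lower numbers for stronger inhibition. Compound 1 `CN(C(=O)NC(=O)c1ccc(F)c(F)c1)c1nc(C(F)(F)F)c(C(=O)N/N=C/c2ccc(C(F)(F)F)cc2)s1` gives 6.26 ug/mL in this assay. Compound 2 `CN(C(=O)NC(=O)c1ccc(Cl)cc1Cl)c1nc(C(F)(F)F)c(C(=O)N/N=C/c2ccc(C(F)(F)F)cc2)s1` gives 12.4 ug/mL in this assay. Compound 3 `CN(C(=O)NC(=O)c1ccc(F)c(F)c1)c1nc(C(F)(F)F)c(C(=O)N/N=C/c2cc(C(F)(F)F)cc(C(F)(F)F)c2)s1` gives 5.47 ug/mL in this assay.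

Compound 1 and compound 2 differ in one place only, (2,4-dichlorophenyl in place of 3,4-difluorophenyl on a carbonyl carbon), and the step that this change made reads a 2.0-fold higher number from compound 1 to compound 2 (0.30 log units; within the scatter). Compound 3 and compound 1 differ in more than one place, and the difference between the two cores is not broken down here; their two values lie close to one another, while the gap between compound 3 and compound 2 is wider.

Compound 4 `CN(C(=O)NC(=O)c1ccc(Cl)cc1Cl)c1nc(C(F)(F)F)c(C(=O)N/N=C/c2cc(C(F)(F)F)cc(C(F)(F)F)c2)s1` has not yet been run. It relates to compound 3 exactly as compound 2 relates to compound 1: 2,4-dichlorophenyl in place of 3,4-difluorophenyl on a carbonyl carbon, at the same place in both pairs. Going by the values given here, the only measured instance of this change is the one from compound 1 to compound 2, which stayed within the usual scatter. Among the compounds with values here, on that basis the step from compound 3 to compound 4 in this assay is expected to be of about the same size, a 2.0-fold higher number from compound 3 to compound 4 (0.30 log units; within the scatter), resting on the single observed step of a 2.0-fold higher number from compound 1 to compound 2 (0.30 log units; within the scatter) and on the value of compound 3 at 5.47 ug/mL. The expected value for compound 4 in this assay is therefore estimated at 11 ug/mL, with a plausible range from 5.5 ug/mL to 22 ug/mL. With one prior example only, the direction of the step is weakly supported and the range is kept wide.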

Compound 4, half-maximal inhibitory concentration: > 100 ug/mL
Compound 4 ended at the assay's limit; the forecaster's own chance of this, stated with the estimate: 5%; middle value at least 9.0-fold (0.95 log units) away from the limit.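

In this assay compound 4 gives > 100 ug/mL, which is a limit of the assay and not a number. Placing 2,4-dichlorophenyl in place of 3,4-difluorophenyl on the carbonyl carbon reads an at least 18-fold higher number from compound 3 to compound 4 (1.26 log units; beyond the scatter), so in these two pairs the size of the step did not carry from one core to the other: the same change on two cores in this assay, a 2.0-fold higher number (0.30 log units; within the scatter) from compound 1 to compound 2 and an at least 18-fold higher number (1.26 log units; beyond the scatter) from compound 3 to compound 4, at least 9.2-fold (0.96 log units) apart, beyond the scatter of two such steps This shows that the step measured on the core of compound 1 is a poor guide to the step on the core of compound 3, but it does not show which feature of the two cores sets the difference, and with compound 4 at the limit the full size of the larger step stays unknown.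

The compounds shown pair only these two aryl groups on the carbonyl carbon and only two cores, both bearing trifluoromethyl groups on the far phenyl ring, so two pairs give no general rule for the series. As far as these compounds go, it remains open whether a plain phenyl or a methoxyphenyl on that carbonyl carbon, or a nitrile in place of trifluoromethyl on the far phenyl ring, would follow the pair of compound 1 and compound 2 or the pair of compound 3 and compound 4.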